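Replacing a diaryl urea with a benzamide on a pyrazole core

This account rests on a few compounds, and the source may have more. Where it says the series, first, only, none or still open, it means among the compounds named here.

Measured compounds and their values:
Compound 1 `COc1cc(-c2nn(-c3cccc(NC(=O)Nc4ccc(Cl)c(Cl)c4)c3)cc2-c2ccncc2)ccc1Cl` gives 1180 nM in a functional assay on IGROV-1 cells (Homo sapiens) for inhibition, read by sulforhodamine B assay, with a stated time of 48 h; on this read-out lower numbers stand for stronger inhibition of growth and higher numbers for weaker inhibition of growth.
Compound 2 `O=C(Nc1cccc(-n2cc(-c3ccncc3)c(-c3ccc(Cl)c(O)c3)n2)c1)Nc1ccc(Cl)c(Cl)c1` gives 1770 nM in this assay.
Compound 3 `O=C(Nc1cccc(-n2cc(-c3ccncc3)c(-c3ccc(Cl)c(O)c3)n2)c1)Nc1cc(C(F)(F)F)cc(C(F)(F)F)c1` gives 896 nM in this assay.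

Compound 1 stands second highest of the three numbers; compound 3 sits a little below it and compound 2 a little above it, with both gaps within the scatter of this measurement. For the measured compounds named here, the only step between compounds that differ in one place, a 1.5-fold higher number from compound 1 to compound 2 (0.18 log units; within the scatter), swaps methyl for hydrogen on an oxygen on an aromatic ring and moves the number hardly at all.

Compound 4 `COc1cc(-c2nn(-c3cccc(NC(=O)c4ccccc4)c3)cc2-c2ccncc2)ccc1Cl` differs from compound 1 in a different part of the molecule: phenyl in place of (3,4-dichlorophenyl)amino on a carbonyl carbon. In short, the urea of compound 1 becomes a simple benzamide. Going by the values given here, no measured step speaks directly to this change. Compounds 2 and 3 carry different groups on the far side of the urea; compound 2 gives 1770 nM and compound 3 gives 896 nM, showing that altering this end of the molecule does not move the number far. Since losing the hydrogen-bond donor and both chlorines is a larger change than any measured here, the expected outcome for compound 4 is a somewhat higher number, a 2.5-fold higher number from compound 1 to compound 4 (0.41 log units; beyond the scatter), with wide uncertainty. The estimate for compound 4 is 3000 nM, expected between 1000 nM and 10000 nM.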

Compound 4, concentration for 50% growth inhibition: 534 nM
The estimate for compound 4 lay 5.6-fold (0.75 log units) above the measured number; measured number below the stated range.
By their numbers in this assay, from the lowest: compounds 4, 3, 1 and 2 (each within the scatter of the next, the first and the last beyond it).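

In this assay, for the compounds shown here, a 2.2-fold lower number from compound 1 to compound 4 (0.34 log units; beyond the scatter) is a modest step, yet it lies beyond the scatter, whereas the one earlier step, a 1.5-fold higher number from compound 1 to compound 2 (0.18 log units; within the scatter), stayed within it. This shows that the (3,4-dichlorophenyl)amino group on the carbonyl carbon is not needed to keep the number at the level of compound 1, even though it brings a hydrogen-bond donor and two chlorines that phenyl lacks. No measurement here explains the lower number, and this single step cannot separate the loss of the amino link from the loss of the two chlorines.

The phenyl of compound 4 carries no further group, so the compounds shown leave open how the number would respond to an amine, a carboxylic acid or a single chlorine on that ring. They also leave open whether a short chain of carbon atoms in place of phenyl on the same carbonyl carbon would hold the number of compound 4, which would show whether an aromatic ring is needed there at all.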